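The source may hold more compounds than are shown below. What is called first, only, known or untested is meant among the compounds shown, and "the series" means these compounds.

Of the compounds shown here, three built on one shared core have been tested in a functional assay on Right cardiac atrium for agonist activity at histamine H2 receptor (Cavia porcellus), with a stated time of 30 min, in the presence of a further agent that is not named here; a lower number here means a smaller maximal response, a higher number a larger maximal response. Compound 1 `Cc1nc(N)sc1CCCN/C(N)=N/C(=S)N[C@@H](C)c1ccccc1` gives 0.65, compound 2 `Cc1nc(N)sc1CCCN/C(N)=N/C(=O)NC(C)c1ccc(OC(F)(F)F)cc1` gives 0.61, and compound 3 `Cc1nc(N)sc1CCCN/C(N)=N/C(=O)N[C@H](C)c1ccccc1` gives 0.95. Compound 2 therefore shows the lowest of the three numbers; its value and that of compound 1 lie within the usual scatter of each other, while compound 3 stands beyond the scatter above it. Compound 4 `Cc1nc(N)sc1CCCN/C(N)=N/C(=O)NC(C)c1ccc(Cl)cc1` differs from compound 2 in one place: chloro in place of trifluoromethoxy on an aromatic carbon. For the measured compounds named here, no measured pair shows this change, so its size must be guessed. Compound 3, which carries no group at that place, gives 0.95, suggesting room upward. Compound 4 is expected to give about 0.72, between 0.55 and 0.9. The expected step is a number 0.11 higher from compound 2 to compound 4 (beyond the scatter), a modest rise.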

Compound 4, intrinsic activity: the largest response reached, as a fraction of the reference agonist's: 0.93
Estimate against measurement, compound 4: 0.21 below; the whole stated range lies below it.
By their numbers in this assay, from the lowest: compounds 2 and 1 (each within the scatter of the next); then compounds 4 and 3 (each within the scatter of the next).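

In this assay, the group on this aromatic carbon proves to matter: chloro in place of trifluoromethoxy gives a number 0.32 higher from compound 2 to compound 4 (beyond the scatter). So the maximal response at this place responds strongly to a single swap, one that replaces a group of five heavy atoms with a single atom. Nothing measured here tells why the response rises. Open, from the compounds shown here alone, is how a methyl, a methoxy or an amine at this same place would compare with chloro. Also open, going by these compounds, is whether fluoro or bromo would behave like chloro.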